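The compounds below may be only part of what the source reports. "The series", "measured", "known", "first", "only" and "open" are said of these compounds alone.

Measured compounds in the series:
- compound 1 `CC1(C)S[C@@H]2/C(=C\C(=O)c3ccc(C(F)(F)F)cc3)C(=O)N2[C@H]1C(=O)OC(c1ccccc1)c1ccccc1`: 26700 nM
- compound 2 `CC1(C)[C@H](C(=O)OC(c2ccccc2)c2ccccc2)N2C(=O)/C(=C/C(=O)c3ccccc3)[C@H]2S1(=O)=O`: 17500 nM
- compound 3 `CC1(C)S[C@@H]2C/C(=C\C(=O)c3ccccc3)C(=O)N2[C@H]1C(=O)OC(c1ccccc1)c1ccccc1`: > 100000 nM

In a functional assay on A-375 cells (Homo sapiens) for cytotoxicity, read by MTT assay, with a stated time of 48 h (a higher number here means a weaker inhibitor, a lower number a stronger inhibitor), compound 1 gives 26700 nM, the highest of the two numbers shown. The nearest number is that of compound 2, at 17500 nM, and the two lie within the scatter of each other, so no order between compound 1 and compound 2 can be read from them. Compound 3 gives only a limit, > 100000 nM, and not a number. One of the three values shown thus sits at the limit (the limit of > 100000 nM in this assay, at which 1 of the 3 values shown sits).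

Compound 4 `CC1(C)S[C@@H]2/C(=C\C(=O)OCc3ccccc3)C(=O)N2[C@H]1C(=O)OC(c1ccccc1)c1ccccc1` has not been measured in this assay. It differs from compound 1 in one place: benzyloxy in place of 4-(trifluoromethyl)phenyl on a carbonyl carbon. Within the data shown here, no step between measured compounds covers this change, so the expectation rests on compound 1 alone. A modest step in this assay, towards a higher number, is expected, a 1.5-fold higher number from compound 1 to compound 4 (0.18 log units; within the scatter), with the chance of reaching the limit not small. For compound 4 the estimate is 40000 nM, within 12000 nM to 130000 nM.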

Compound 4, half-maximal inhibitory concentration: 7100 nM
Beside the measured number, compound 4's estimate is 5.6-fold (0.75 log units) above it, and the stated range ends above it.
By their numbers in this assay, from the lowest: compound 4; then compounds 2 and 1 (each within the scatter of the next). At a limit, above all of these: compound 3.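

In this assay, among these compounds, benzyloxy in place of 4-(trifluoromethyl)phenyl on a carbonyl carbon gives a 3.8-fold lower number from compound 1 to compound 4 (0.58 log units; beyond the scatter), the first step that can be read at this position. The number therefore responds to the group on this carbonyl carbon, and compound 4 gives a measured number and not a limit. Both groups carry one six-membered aromatic ring of carbon only, so the step arises with such a ring retained, but nothing at hand accounts for its size.

This single step cannot separate the loss of the trifluoromethyl from the entry of the benzyloxy oxygen. As far as these compounds go, how a carboxylic acid, an amine or a longer chain on the same carbonyl carbon would read also remains open.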